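A 2,6-Difluoropyridin-4-yl Group Replaces 2,6-Dimethylpyridin-4-yl

The source may report more compounds than this note shows. Statements on the series, on what has been measured and on what is new or still open speak of the compounds shown alone.

Within the data shown here, in a toxicity assay on MT4 cells (Homo sapiens) for cytotoxicity, read by MTT assay, with a stated time of 5 days (on this read-out higher numbers stand for lower toxicity in this test and lower numbers for higher toxicity in this test), compound 2 `Cc1cc(-c2cc(C)c(Nc3ccnc(Nc4ccc(C#N)cc4)n3)c(C)c2)cc(C)n1` gives 2300 nM and stands lowest of the two numbers so far, while compound 1 `Cc1cc(-c2cc3ccccc3s2)cc(C)c1Nc1ccnc(Nc2ccc(C#N)cc2)n1` gives 138000 nM on the same read-out. The change to compound 3 `Cc1cc(-c2cc(F)nc(F)c2)cc(C)c1Nc1ccnc(Nc2ccc(C#N)cc2)n1` puts 2,6-difluoropyridin-4-yl in place of 2,6-dimethylpyridin-4-yl on an aromatic carbon. Among the measured compounds shown here, only one measured step bears on this, and it was made at the same place: replacing 1-benzothiophen-2-yl with 2,6-dimethylpyridin-4-yl gave a 60-fold lower number from compound 1 to compound 2 (1.78 log units; beyond the scatter) and was large. The number in this assay can therefore move far with the group on that carbon. Here the two groups differ less, so a smaller step is expected, and with compound 2 holding the lowest number known, an upward move seems likelier. This amounts to an estimated 3.5-fold higher number from compound 2 to compound 3 (0.54 log units; beyond the scatter) and remains a rough expectation. Compound 3 is estimated at 8000 nM (range 2000 nM to 35000 nM).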

Compound 3, half-maximal cytotoxic concentration: 6300 nM
Beside the measured number, compound 3's estimate is 1.3-fold (0.10 log units) above it, and the stated range covers the measured number.
By their numbers in this assay, from the lowest: compound 2; then compound 3; then compound 1.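

In this assay, the ring stays a pyridin-4-yl and only its two outer groups change, yet fluorine in place of methyl gives a 2.7-fold higher number from compound 2 to compound 3 (0.44 log units; beyond the scatter). The number at this position therefore depends on the groups carried by the pyridine ring, not only on the ring itself, although this shift is much smaller than the one seen when the whole group was exchanged. The difluoro group also keeps most of that earlier drop, with a 22-fold lower number from compound 1 to compound 3 (1.34 log units; beyond the scatter), so both pyridin-4-yl groups stand well under the 1-benzothiophen-2-yl group, and nothing shown gives a reason for either step.

The compounds shown leave open how an unsubstituted pyridin-4-yl, a phenyl or a 2,6-dimethoxypyridin-4-yl group would fall in this order. They also leave open where an amine in place of the fluorines would stand.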